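The source may hold more compounds than are shown below. What is called first, only, known or untested is meant among the compounds shown, and "the series" means these compounds.

Measured compounds:
Compound 1, `O=C(c1ccncc1)n1c(-c2cn(-c3ccccc3)nc2-c2ccc(F)cc2)nc2ccccc21`, gives 151000 nM in an ADME assay on HEK-293T cells (Homo sapiens) for cytotoxicity, read by MTT assay, with a stated time of 24 h; a higher number here means that more compound is tolerated, a lower number that less compound is tolerated.
Compound 2, `Cc1cccc(C(=O)n2c(-c3cn(-c4ccccc4)nc3-c3ccc(F)cc3)nc3ccccc32)c1`, gives 148000 nM in this assay.

Compound 2 and compound 1 lie within the scatter of each other: a 1.0-fold lower number from compound 1 to compound 2 (0.01 log units; within the scatter). On these two numbers compound 2 therefore does not stand apart from compound 1. Compound 3, `O=C(c1ccccc1)n1c(-c2cn(-c3ccccc3)nc2-c2ccc(F)cc2)nc2ccccc21`, is not yet measured. It differs from compound 2 by hydrogen in place of methyl on an aromatic carbon. Going by the values given here, the only measured step that bears on this change sits on the same ring on the carbonyl carbon, a 1.0-fold lower number from compound 1 to compound 2 (0.01 log units; within the scatter), which exchanged the whole ring without moving the number beyond the scatter. A smaller change at that ring, hydrogen in place of methyl, is therefore expected to give no step beyond the scatter, a 1.0-fold higher number from compound 2 to compound 3 (0.01 log units; within the scatter). Compound 3 is estimated at 150000 nM, with a range from 75000 nM to 300000 nM.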

Compound 3, half-maximal cytotoxic concentration: 180000 nM
Beside the measured number, compound 3's estimate is 1.2-fold (0.08 log units) below it; the range from low to high includes it.
By their numbers in this assay, from the lowest: compounds 2, 1 and 3 (each within the scatter of the next).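

In this assay, the methyl at this position of the 3-methylphenyl ring can be replaced by hydrogen without a step beyond the scatter (a 1.2-fold higher number from compound 2 to compound 3 (0.09 log units; within the scatter)). The earlier step had exchanged pyridin-4-yl for 3-methylphenyl, altering the ring and adding the methyl in one move, whereas the phenyl compound now separates those two changes: phenyl in place of pyridin-4-yl on the carbonyl carbon also stays within the scatter (a 1.2-fold higher number from compound 1 to compound 3 (0.08 log units; within the scatter)). No measurement shown here gives a reason for these results.

The compounds shown leave open whether an amine or a carboxylic acid on this ring, or a longer chain in place of the methyl, would give a step beyond the scatter. They also leave open what a change elsewhere on the shared core would do, since all of them keep it unchanged.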